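Adding a bromo group to compound 3

A few compounds are considered here, and "the series" means these few. Any claim that something is new, unique, unknown or untested is made for them only; others in the source may bear on it.

compound 1 (`Cc1ccccc1/C=C/c1ncc([N+](=O)[O-])n1C`) gives 93300 nM
compound 2 (`Cn1c([N+](=O)[O-])cnc1/C=C/c1cccc(Cl)c1`) gives 30200 nM
compound 3 (`Cn1c([N+](=O)[O-])cnc1CCc1ccccc1`) gives > 100000 nM (a limit)

All three results come from an ADME assay on HeLa cells (Homo sapiens) for cytotoxicity, read by resazurin assay, with a stated time of 2 days (a higher number here means a weaker inhibitor, a lower number a stronger inhibitor), as the common measure. Compound 3 stands at > 100000 nM as a limit of the assay, not a number. Compound 4 (`Cn1c([N+](=O)[O-])cnc1CCc1ccc(Br)cc1`) differs from compound 3 by one change (bromo in place of hydrogen on an aromatic carbon): bromo in place of hydrogen on an aromatic carbon, para to a large group. Going by the values given here, no measured pair shows this change alone. The expectation leans on compound 1 at 93300 nM and compound 2 at 30200 nM, which carry ring substituents and return numbers, though their link differs from that of compound 3. A modest move toward a lower number is expected, with the estimated step of an at least 1.6-fold lower number from compound 3 to compound 4 (0.22 log units; that floor lies within the scatter) in this assay as the working figure. Compound 4 is estimated at 60000 nM with an expected range from 25000 nM to 100000 nM as its bounds.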

Compound 4, half-maximal inhibitory concentration: 97700 nM
Compound 4: the middle estimate sits 1.6-fold (0.21 log units) below what was measured, and the stated range covers the measured number.
By their numbers in this assay, from the lowest: compound 2; then compounds 1 and 4 (each within the scatter of the next). At a limit, above all of these: compound 3.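

In this assay compound 4, with its bromo group on the aromatic carbon, gives 97700 nM as a readable number. Going by these compounds, compound 3 stands at > 100000 nM as a limit of the assay and not a number, so the change reads only as an at least 1.0-fold lower number from compound 3 to compound 4 (0.01 log units; that floor lies within the scatter) and its true size stays open. One end of this step rests on a limit: the limit of > 100000 nM in this assay, at which 1 of the 4 values shown sits. The compounds shown leave open what an amine or a carboxylic acid at this same place would do to the number. They also leave open how a longer chain in the link would read with the bromo group kept.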